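Moving the Hydroxy Group Along the Pyridinyl Alkyne

The source may hold more compounds than are shown below. What is called first, only, known or untested is meant among the compounds shown, and "the series" means these compounds.

Compound 2 `Cc1ccc(-n2nccn2)c(C(=O)N2C[C@H](C#Cc3cnccc3O)CC[C@H]2C)c1` stands as the weaker of the two measured compounds in an assay on cells for binding affinity to Orexin/Hypocretin receptor type 1 (Homo sapiens), read by radioligand binding; a higher number here means a weaker inhibitor, a lower number a stronger inhibitor: compound 2 gives 866 nM, whereas compound 1 `Cc1ccc(-n2nccn2)c(C(=O)N2C[C@H](C#Cc3cccnc3)CC[C@H]2C)c1` gives 107 nM. For the measured compounds named here, the single measured step, an 8.1-fold higher number from compound 1 to compound 2 (0.91 log units; beyond the scatter), describes the gain of a hydroxy group rather than its relocation.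

Compound 3 `Cc1ccc(-n2nccn2)c(C(=O)N2C[C@H](C#Cc3cccnc3O)CC[C@H]2C)c1` keeps every atom of compound 2 but joins them differently: 2-hydroxypyridin-3-yl in place of 4-hydroxypyridin-3-yl on a triple-bonded carbon. Going by the values given here, no measured pair shows what follows when the hydroxy group moves from one carbon of the pyridinyl ring to another, so the step from compound 1 to compound 2 bears on compound 3 only indirectly, as a sign that a hydroxy group on this ring can move the number by a modest amount in either direction. Among the compounds with values here, with no direct precedent, the expectation for compound 3 is a number close to that of compound 2, with a wide margin on both sides. Compound 3 is therefore estimated at 600 nM, within a range of 150 nM to 2500 nM. The expected step, a 1.4-fold lower number from compound 2 to compound 3 (0.16 log units; within the scatter), is estimated to stay within the scatter.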

Compound 3, inhibition constant: 24 nM
The estimate for compound 3 lay 25-fold (1.40 log units) above the measured number; the whole stated range lies above it.
By their numbers in this assay, from the lowest: compound 3; then compound 1; then compound 2.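

In this assay, 2-hydroxypyridin-3-yl in place of 4-hydroxypyridin-3-yl on a triple-bonded carbon gives a 36-fold lower number from compound 2 to compound 3 (1.56 log units; beyond the scatter), so where the hydroxy group sits on this ring counts for more than the earlier pair could show. Hydroxy in place of hydrogen on an aromatic carbon gave an 8.1-fold higher number from compound 1 to compound 2 (0.91 log units; beyond the scatter), but the same kind of change now gives a 4.5-fold lower number from compound 1 to compound 3 (0.65 log units; beyond the scatter), so among these compounds adding a hydroxy group can shift the number either way, depending on the carbon that carries it. Compound 3 therefore holds the lowest number of the three, with its steps to compound 1 and compound 2 both beyond the scatter, and the hydroxy group is not simply a burden on this ring.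

Nothing at hand explains why these two hydroxypyridinyl groups, with the same atoms and the same counts of donors and acceptors, part so widely. On these data alone, it also remains open whether a methoxy group or an amine on the carbon that bears the hydroxy group in compound 3 would keep a number this low, or whether the hydroxy group itself is needed.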